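Propyl for dimethylamino on the sulfonyl sulfur

This account rests on a few compounds, and the source may have more. Where it says the series, first, only, none or still open, it means among the compounds named here.

In an in vivo ADME assay on the whole organism (strain BALB/c) for pharmacokinetics, with Mus musculus as the target, read by LC-MS, at a dose of 5 mg/kg by the oral route (a higher number here means that a larger share of the oral dose reaches the circulation, a lower number that a smaller share of the oral dose reaches the circulation), compound 1 `CCCS(=O)(=O)c1cccc(C#Cc2cc(Cl)ccc2OCC(=O)O)c1` gives 37% and compound 2 `CN(C)S(=O)(=O)c1ccc(F)c(C#Cc2cc(Cl)ccc2OCC(=O)O)c1` gives 58% as the higher of the two numbers, a gap beyond the scatter. Compound 3 `CCCS(=O)(=O)c1ccc(F)c(C#Cc2cc(Cl)ccc2OCC(=O)O)c1` carries propyl in place of dimethylamino on a sulfonyl sulfur and awaits measurement. Within the data shown here, no measured pair isolates this change. Compound 1 also bears propyl on its sulfonyl sulfur and stands lower at 37% so a moderate fall is expected. The expected fall is estimated as a number 13 percentage points lower from compound 2 to compound 3 (beyond the scatter) and lies near the edge of the scatter. Compound 3 is estimated at 45% with an expected range from 27% to 63% in this series.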

Compound 3, oral bioavailability: 63%
The estimate for compound 3 lay 18 percentage points below the measured number, within the range that was stated.
By their numbers in this assay, from the lowest: compound 1; then compounds 2 and 3 (each within the scatter of the next).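

In this assay, propyl in place of dimethylamino on a sulfonyl sulfur gives a number 5 percentage points higher from compound 2 to compound 3 (within the scatter), so with the fluoro present the two sulfonyl groups are not told apart. With propyl held on the sulfonyl sulfur, fluoro in place of hydrogen on an aromatic carbon gives a number 26 percentage points higher from compound 1 to compound 3 (beyond the scatter), and of these two single changes only this one lies beyond the scatter. Nothing measured on these compounds accounts for either step.

Open, from the compounds shown here alone, is whether a morpholine or a longer chain such as butyl on the sulfonyl sulfur keeps oral bioavailability at this level. Also open, going by these compounds, is whether chloro in place of fluoro on that aromatic carbon gives a step of similar size.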